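Swapping a Pyrrolidine onto the Acrylamide Tail

The source may report more compounds than this note shows. Statements on the series, on what has been measured and on what is new or still open speak of the compounds shown alone.

Compound 2 `CCC/C=C/C(=O)Nc1cc2c(N3CCCc4ccccc43)ncnc2cc1O[C@@H]1CCOC1` is the weaker of the two measured compounds in a functional assay on PC-3 cells (Homo sapiens) for antiproliferative activity, read by MTT assay, with a stated time of 72 h; a higher number here means a weaker inhibitor, a lower number a stronger inhibitor: compound 2 gives 11800 nM, whereas compound 1 `CCC/C=C/C(=O)Nc1cc2c(N3CCCc4ccccc43)ncnc2cc1OC` gives 2240 nM. Among the compounds with values here, the single measured step, a 5.3-fold higher number from compound 1 to compound 2 (0.72 log units; beyond the scatter), concerns only the ether group on the aromatic ring. Compound 3 `O=C(/C=C/CN1CCCC1)Nc1cc2c(N3CCCc4ccccc43)ncnc2cc1O[C@@H]1CCOC1` keeps the oxolan-3-yl ether of compound 2 and instead alters the unsaturated amide chain: pyrrolidin-1-yl in place of ethyl on a saturated chain carbon bound to a double-bonded chain carbon. Within the data shown here, no measured step touches this part of the molecule, so the data give no guidance on the size or direction of the change in this assay . With nothing to point either way, the step of a 1.5-fold lower number from compound 2 to compound 3 (0.17 log units; within the scatter) is therefore expected to stay within the usual scatter, though the range is kept wide. The estimate for compound 3 in this assay is 8000 nM, with a range from 2000 nM to 30000 nM.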

Compound 3, half-maximal inhibitory concentration: 5780 nM
Beside the measured number, compound 3's estimate is 1.4-fold (0.14 log units) above it; the range from low to high includes it.
By their numbers in this assay, from the lowest: compound 1; then compound 3; then compound 2.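

Within the data shown here, this step gives the first reading on the unsaturated amide chain, as the earlier step touched only the ether group. In this assay, pyrrolidin-1-yl in place of ethyl on a saturated chain carbon bound to a double-bonded chain carbon gives a 2.0-fold lower number from compound 2 to compound 3 (0.31 log units; beyond the scatter), so this position accepts a larger group containing a ring and a nitrogen with no loss of activity. Nothing measured here accounts for this shift.

The compounds shown leave open whether the gain follows the ring or the nitrogen, which an open-chain amine such as dimethylamino or a ring such as piperidine or morpholine on the same chain carbon could help separate. As far as these compounds go, it also remains open whether the same swap would move the number the same way with the methyl ether of compound 1.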